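A Methyl Group Tried on a Second Core

The source may report more compounds than this note shows. Statements on the series, on what has been measured and on what is new or still open speak of the compounds shown alone.

The study compares three measured compounds and one still awaiting measurement. Compound 1 `N/C(=N\NC(=S)N1CCCCCC1)c1ccccn1` is tested in a functional assay on A-431 cells (Homo sapiens) for cytotoxicity, read by MTT assay, with a stated time of 72 h, tested at 1 uM (a higher number here means more inhibition of growth at the concentration tested, a lower number less inhibition of growth), where compound 1 gives 18.8%. Compound 3 `N/C(=N\NC(=S)N1CCSCC1)c1ccccn1` rests on a different core; the difference between the two cores is not broken down here. In this assay compound 3 gives 31.7%, and compound 1 stands lowest of the three, beyond the scatter below compound 3. Compound 2 `Cc1ccnc(/C(N)=N/NC(=S)N2CCSCC2)c1` carries the change methyl in place of hydrogen on an aromatic carbon on the core of compound 3, and in this assay compound 2 gives 34.6%. The step of a number 2.9 percentage points higher from compound 3 to compound 2 (within the scatter) lies within the scatter, so on that core the methyl group makes no difference that can be told apart from repeat-to-repeat variation.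

Compound 4 `Cc1ccnc(/C(N)=N/NC(=S)N2CCCCCC2)c1` applies the same change to compound 1: methyl in place of hydrogen on an aromatic carbon. The two place descriptions agree word for word, so the change is counted as the same one. Among the measured compounds shown here, only one measured pair shows what it does, and that pair sits on the other core. The account expects compound 4 to stay close to compound 1, with an estimated step of a number 3.2 percentage points higher from compound 1 to compound 4 (within the scatter) set beside the measured a number 2.9 percentage points higher from compound 3 to compound 2 (within the scatter). For the measured compounds named here, this expectation rests on compound 1, because compound 1 gives 18.8% and the one known step is small. Compound 4 is therefore estimated at 22%, with an expected range from 8% to 36%.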

Compound 4, percent growth inhibition at one concentration: 36.3%
For compound 4 the middle estimate is 14.3 percentage points below the measured one; measured number above the stated range.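

In this assay, methyl in place of hydrogen on an aromatic carbon gives a number 17.5 percentage points higher from compound 1 to compound 4 (beyond the scatter), so on the core of compound 1 the change can be told apart from repeat-to-repeat variation. The size of the step did not carry over from one core to the other: the same change on two cores in this assay, a number 2.9 percentage points higher (within the scatter) from compound 3 to compound 2 and a number 17.5 percentage points higher (beyond the scatter) from compound 1 to compound 4, 14.6 percentage points apart, beyond the scatter of two such steps. Among the compounds shown here, this shows that, in this series, a step measured on one core is not a safe guide to the step on the other, but with only one pair on each core, it does not show why the two differ or what the change would do on any further core.

The compounds shown leave open whether another group on the same aromatic carbon, such as an ethyl group, a methoxy group, a chlorine atom or an amine, would give a large step on the core of compound 1 and a small one on the core of compound 3. They also leave open whether the two cores would part in the same way with the methyl group on a different carbon of the six-membered aromatic ring.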